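The compounds below may be only part of what the source reports. "The series", "measured", "known", "first", "only" and "open" are said of these compounds alone.

Measured compounds in a functional assay on HepG2 cells (Homo sapiens) for cytotoxicity, with a stated time of 72 h; a lower number here means that less compound is needed, a higher number that more compound is needed for the effect:
compound 1 `C=C[C@@](C)(/C=C/c1ccc(OCc2ccccc2)cc1)CCC=C(C)C` gives > 52000 nM, a limit of the assay.
compound 2 `C=C[C@@](C)(/C=C/c1ccc(O)c(/C=C/C(=O)c2ccccc2)c1)CCC=C(C)C` gives > 52000 nM, a limit of the assay.
compound 3 `C=C[C@@](C)(/C=C/c1ccc(O)c(/C=C/C(=O)OCC)c1)CCC=C(C)C` gives > 52000 nM, a limit of the assay.

Compound 1 stands only at a limit in this assay, and the two other measured compounds stand at the same limit, all three sitting at the limit of > 52000 nM in this assay, at which 3 of the 3 values shown sit. Among the measured compounds shown here, the one step between measured compounds that differ in one place, a step that the two limits leave unreadable from compound 2 to compound 3, is unreadable. Compound 4 `C=C[C@@](C)(/C=C/c1ccc(Nc2ccc(Cl)c(Cl)c2)cc1)CCC=C(C)C` differs from compound 1 by (3,4-dichlorophenyl)amino in place of benzyloxy on an aromatic carbon. For the measured compounds named here, no measured step bears on this change: the step from compound 2 to compound 3 concerns another place in the shared core and is unreadable in any case. With every value so far at the limit of > 52000 nM in this assay, at which 3 of the 3 values shown sit, nothing shown points to a step in either direction beyond the scatter, so the expected step that the limit leaves unreadable from compound 1 to compound 4 is none beyond the scatter, with a high chance that only a limit is reported again. Compound 4 is expected at about 60000 nM, with a range from 25000 nM to 150000 nM.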

Compound 4, half-maximal effective concentration: > 52000 nM
Compound 4: no number, only a limit (the forecaster's own chance of this, stated with the estimate: 75%); the middle value does not contradict the limit.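

No step can be read from compound 1 to compound 4 in this assay, as both give only a limit, like every compound shown: the limit of > 52000 nM in this assay, at which 4 of the 4 values shown sit.

The compounds shown leave open how (3,4-dichlorophenyl)amino compares with benzyloxy, and whether any change to the shared core gives a readable number.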